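Swapping methyl for cyano on a benzyl group

The source may hold more compounds than are shown below. What is called first, only, known or untested is meant among the compounds shown, and "the series" means these compounds.

Measured compounds:
- compound 1, `COC(=O)/C=C/c1ccc2c(c1)C(=O)C(=O)N2Cc1ccc(C)cc1`: 40 nM in a functional assay on K562 cells (Homo sapiens) for cytotoxicity, read by MTT assay, with a stated time of 48 h; a lower number here means a stronger inhibitor, a higher number a weaker inhibitor
- compound 3, `COC(=O)/C=C/c1ccc2c(c1)/C(=N/O)C(=O)N2Cc1ccc(Br)cc1`: 2920 nM in this assay
- compound 2, `CCCCc1ccc2c(c1)C(=O)C(=O)N2`: > 10000 nM in this assay, which is a limit of the assay, not a number

Compound 1 gives the lowest of the two numbers shown. Its nearest neighbour, compound 3, sits beyond the scatter above it, yet compound 3 differs from compound 1 in two places at once, so those two values only show a gap and nothing about either change alone. Compound 2 is reported only as a limit (the limit of > 10000 nM in this assay, at which 1 of the 3 values shown sits).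

The unmeasured compound 4, `COC(=O)/C=C/c1ccc2c(c1)C(=O)C(=O)N2Cc1ccc(C#N)cc1`, differs from compound 1 in one place: cyano in place of methyl on an aromatic carbon. For the measured compounds named here, no pair of measured compounds separated by a single change is available here, so nothing in the data says how this kind of exchange on the benzyl ring shifts the number in this assay. The expectation is therefore a step near zero, within the usual scatter, with a slight lean toward a higher number. The step from compound 1 to compound 4 is estimated at a 1.5-fold higher number from compound 1 to compound 4 (0.18 log units; within the scatter). Compound 4 is expected to give about 60 nM, within the range 15 nM to 250 nM.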

Compound 4, half-maximal inhibitory concentration: 30 nM
The estimate for compound 4 lay 2.0-fold (0.30 log units) above the measured number; the range from low to high includes it.
By their numbers in this assay, from the lowest: compounds 4 and 1 (each within the scatter of the next); then compound 3. At a limit, above all of these: compound 2.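

In this assay, the only single-change step among the compounds shown is a 1.3-fold lower number from compound 1 to compound 4 (0.12 log units; within the scatter), which lies within the usual scatter, so this exchange cannot be told apart from no change at all. For the compounds shown here, this gives the first direct reading at this place on the benzyl ring, para to a large group: going from 4-methylphenyl to 4-cyanophenyl adds a heavy atom and a hydrogen-bond acceptor, yet the number stays within the scatter of the one for compound 1. Nothing among the measurements shown explains why these two groups give such similar numbers.

As far as these compounds go, this single pair cannot show whether the same place would also accept an amine, a carboxylic acid or a longer chain such as butyl, so how far the tolerance extends remains open. Compound 3 differs from compound 1 in two places, so the effect of each of those changes alone also cannot be read from the compounds shown.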